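Amide aryl variation in a flavonol series

The source may report more compounds than this note shows. Statements on the series, on what has been measured and on what is new or still open speak of the compounds shown alone.

Measured compounds in a functional assay on HeLa cells (Homo sapiens) for antiproliferative activity, read by CCK-8 assay, with a stated time of 72 h; a higher number here means a weaker inhibitor, a lower number a stronger inhibitor:
Compound 1 `Cc1ccccc1C(=O)Nc1cccc(-c2oc3cc(-c4ccc(F)cc4)ccc3c(=O)c2O)c1` gives 11900 nM.
Compound 2 `O=C(Nc1cccc(-c2oc3cc(-c4ccc(F)cc4)ccc3c(=O)c2O)c1)c1ccc(Br)cc1` gives 9740 nM.
Compound 3 `O=C(Nc1cccc(-c2oc3cc(-c4ccc(F)cc4)ccc3c(=O)c2O)c1)c1cccc(F)c1` gives 8780 nM.

Compound 1 carries the highest of the three numbers, yet both steps away from it, a 1.2-fold lower number from compound 1 to compound 2 (0.09 log units; within the scatter) and a 1.4-fold lower number from compound 1 to compound 3 (0.13 log units; within the scatter), stay within the scatter, as does a 1.1-fold lower number from compound 2 to compound 3 (0.05 log units; within the scatter). The three measured compounds thus cannot be separated from one another.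

Compound 4 `O=C(Nc1cccc(-c2oc3cc(-c4ccc(F)cc4)ccc3c(=O)c2O)c1)c1ccc(Cl)nc1` differs from compound 1 in one place: 6-chloropyridin-3-yl in place of 2-methylphenyl on a carbonyl carbon. For the measured compounds named here, every measured step so far exchanges the group on that same carbonyl carbon, and none of them moved the number beyond the scatter, so a further exchange of this kind is expected to change little. Compound 4 is therefore expected near 9500 nM (range 4500 nM to 20000 nM), an estimated step of a 1.3-fold lower number from compound 1 to compound 4 (0.10 log units; within the scatter) that should remain within the scatter.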

Compound 4, half-maximal inhibitory concentration: 4080 nM
Estimate against measurement, compound 4: 2.3-fold (0.37 log units) above, outside the stated range (below it).
By their numbers in this assay, from the lowest: compound 4; then compounds 3, 2 and 1 (each within the scatter of the next).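

The group on the carbonyl carbon can move the number after all: in this assay, 6-chloropyridin-3-yl gives a 2.9-fold lower number from compound 1 to compound 4 (0.46 log units; beyond the scatter) and a 2.4-fold lower number from compound 2 to compound 4 (0.38 log units; beyond the scatter) as well as a 2.2-fold lower number from compound 3 to compound 4 (0.33 log units; beyond the scatter) in the three exchanges. Compound 4 is the only one of the four with a hetero atom in this ring and a hydrogen-bond acceptor in this group, and its steps to all three others are modest.

Going by these compounds, whether the step follows the ring nitrogen or the chlorine stays open; a pyridin-3-yl or a 4-chlorophenyl group on the same carbonyl carbon would separate the two. No available evidence accounts for the step.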